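This account rests on a few compounds, and the source may have more. Where it says the series, first, only, none or still open, it means among the compounds named here.

Measured compounds:
Compound 1 `CCCN1CCC(CNCc2cn(-c3ccc([N+](=O)[O-])cc3)nc2-c2ccc(OC(F)(F)F)cc2)CC1` gives 18000 nM in an ADME assay on Huh-7 cells (Homo sapiens) for cytotoxicity; on this read-out lower numbers stand for higher toxicity in this test and higher numbers for lower toxicity in this test.
Compound 2 `CN1CCN(CCCNCc2cn(-c3ccc([N+](=O)[O-])cc3)nc2-c2ccc(OC(F)(F)F)cc2)CC1` gives 1600 nM in this assay.

Within the data shown here, on these two numbers compound 1 stands highest, and the only step measured so far runs away from it: an 11-fold lower number from compound 1 to compound 2 (1.05 log units; beyond the scatter), a change that touches the amine side chain, not the aromatic ring. Compound 3 `CCCN1CCC(CNCc2cn(-c3ccc([N+](=O)[O-])cc3)nc2-c2ccc(Cl)cc2)CC1` differs from compound 1 at the other end of the molecule: chloro in place of trifluoromethoxy on an aromatic carbon. Among the measured compounds shown here, no measured step concerns this aromatic substituent, and the single step on record, from compound 1 to compound 2, tells nothing about exchanging trifluoromethoxy for chloro. In the absence of any bearing step, the expectation is no change beyond the usual scatter, in either direction, so compound 3 is expected to sit close to compound 1 in this assay, with no change at the digits printed from compound 1 to compound 3 (within the scatter). Compound 3 is therefore estimated at 18000 nM in this assay, with a range from 7000 nM to 45000 nM.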

Compound 3, half-maximal cytotoxic concentration: 11000 nM
Estimate against measurement, compound 3: 1.6-fold (0.21 log units) above, within the range that was stated.
By their numbers in this assay, from the lowest: compound 2; then compounds 3 and 1 (each within the scatter of the next).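

In this assay the aromatic end of the molecule now has a measured step of its own: chloro in place of trifluoromethoxy, on an aromatic carbon para to a large group, gives a 1.6-fold lower number from compound 1 to compound 3 (0.21 log units; within the scatter) and so stays within the usual scatter. With the 1-propylpiperidin-4-yl side chain held fixed, the 4-chlorophenyl and 4-(trifluoromethoxy)phenyl compounds cannot be told apart in this assay, while the side-chain step, an 11-fold lower number from compound 1 to compound 2 (1.05 log units; beyond the scatter), remains the only one on record beyond the scatter. Nothing on hand explains why this exchange at the aromatic ring stays within the scatter.

Whether a fluoro, a methoxy or a nitrile on the same aromatic carbon would also stay within the scatter remains open, since this position is shown with only trifluoromethoxy and chloro. It is also open whether chloro would read the same way on the 2-(4-methylpiperazin-1-yl)ethyl side chain of compound 2, because the exchange is shown only with the 1-propylpiperidin-4-yl side chain of compound 1.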